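Ether to ester on the oxygen of the saturated ring

This account rests on a few compounds, and the source may have more. Where it says the series, first, only, none or still open, it means among the compounds named here.

Measured so far:
compound 1 `COC1C[C@@H]2CCCC[C@@H]2[C@H]1/C=C/c1ccc(-c2cccc(F)c2)cn1` 67 nM
compound 2 `Fc1cccc(-c2ccc(/C=C/[C@H]3C(OCc4ccccc4)C[C@@H]4CCCC[C@@H]43)nc2)c1` 280 nM

In an assay on cell membranes for displacement of a labelled ligand from proteinase-activated receptor 1 (Homo sapiens), read by scintillation counting, with a stated time of 60 min (on this read-out lower numbers stand for stronger inhibition and higher numbers for weaker inhibition), compound 2 gives 280 nM, the higher of the two numbers; its nearest neighbour is compound 1 with 67 nM. For the measured compounds named here, the only step recorded, a 4.2-fold higher number from compound 1 to compound 2 (0.62 log units; beyond the scatter), shows the larger group on that oxygen giving the weaker result. Compound 3 `CC(=O)OC1C[C@@H]2CCCC[C@@H]2[C@H]1/C=C/c1ccc(-c2cccc(F)c2)cn1` differs from compound 2 by acetyl in place of benzyl on an oxygen on a saturated carbon. The entering group is closer in size to the methyl of compound 1 than to benzyl, so a modest step back toward compound 1 is expected, estimated as a 2.2-fold lower number from compound 2 to compound 3 (0.33 log units; beyond the scatter). For compound 3 the expected value is 130 nM, within a range of 50 nM to 350 nM.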

Compound 3, half-maximal inhibitory concentration: 67 nM
The estimate for compound 3 lay 1.9-fold (0.29 log units) above the measured number; the range from low to high includes it.
By their numbers in this assay, from the lowest: compounds 1 and 3 (each within the scatter of the next); then compound 2.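

Acetyl in place of benzyl on this oxygen gives a 4.2-fold lower number from compound 2 to compound 3 (0.62 log units; beyond the scatter) in this assay, while acetyl in place of methyl gives no change at the digits printed from compound 1 to compound 3 (within the scatter). On this oxygen, therefore, the acetyl ester and the methyl ether cannot be told apart, and among these three compounds only benzyl stands apart. No measurement shown here accounts for this.

Still open, on these data alone, is how a free hydroxyl, an amine or a longer acyl chain such as butyryl would read on this saturated carbon. Also open, as far as these compounds go, is whether benzoyl would track acetyl or benzyl.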